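Exchanging the Benzyl Ester of Compound 3

The source may report more compounds than this note shows. Statements on the series, on what has been measured and on what is new or still open speak of the compounds shown alone.

Compound 1 `COc1ccc2cc([C@H](C)C(=O)OCN(C)C(=O)c3ccccc3)ccc2c1` gives 1.2 h in an ADME assay on a cell-free system (plasma, Homo sapiens) for metabolic stability; a higher number here means that the compound lasts longer, a lower number that the compound disappears faster. Compound 2 `Cc1cc(C)nc(N(COC(=O)c2ccccc2)S(=O)(=O)c2ccc(N)cc2)n1` gives 0.69 h. Compound 3 `O=C(OCc1ccccc1)[C@H]1O[C@@H](Oc2cc3oc(-c4ccc(O)cc4)cc(=O)c3c(O)c2O)[C@H](O)[C@@H](O)[C@@H]1O` gives 1.47 h.

Among these three numbers compound 3 stands highest. Its nearest neighbour is compound 1, whose number lies within the scatter of repeated measurements, so the two cannot be told apart. Compound 2 lies furthest away, with a number beyond the scatter on the lower side.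

Compound 4 `CCN(CC)C(=O)COC(=O)[C@H]1O[C@@H](Oc2cc3oc(-c4ccc(O)cc4)cc(=O)c3c(O)c2O)[C@H](O)[C@@H](O)[C@@H]1O` is the one not yet measured. It differs from compound 3 in one place: diethylcarbamoyl in place of phenyl on a saturated chain carbon bound to an oxygen next to a carbonyl group. Put another way, the benzyl ester of compound 3 becomes a (diethylcarbamoyl)methyl ester in compound 4. For the measured compounds named here, none of the measured pairs shows this exchange, so no measured step can guide the expectation; the three measured compounds differ from one another in many places at once.

With nothing to go on beyond the number for compound 3, the step of a 1.2-fold lower number from compound 3 to compound 4 (0.09 log units; within the scatter) is estimated to be small, in either direction, and not beyond the scatter. Compound 4 is therefore expected to give about 1.2 h in this assay, with a range from 0.5 h to 3 h.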

Compound 4, half-life: 0.167 h
The estimate for compound 4 lay 7.2-fold (0.86 log units) above the measured number, outside the stated range (below it).
By their numbers in this assay, from the lowest: compound 4; then compounds 2, 1 and 3 (each within the scatter of the next, the first and the last beyond it).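

In this assay, diethylcarbamoyl in place of phenyl on a saturated chain carbon bound to an oxygen next to a carbonyl group gives an 8.8-fold lower number from compound 3 to compound 4 (0.94 log units; beyond the scatter), the only step shown in which a single place changes. For the compounds shown here, the rest of the structure is shared by the two compounds, so this step belongs to the exchange of benzyl for (diethylcarbamoyl)methyl, and it shows that the number in this assay is sensitive to what this position carries, which the earlier compounds, differing in many places at once, could not show. Nothing at hand bears on what lies behind the step.

The compounds shown leave open whether the lower number goes with the arrival of the diethylcarbamoyl group or with the departure of the phenyl ring, a question that a plain ethyl ester or a (dimethylcarbamoyl)methyl ester on the same core would help to separate. They also leave open whether the same exchange would give a step of similar size on a different core, such as that of compound 1.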